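This account rests on a few compounds, and the source may have more. Where it says the series, first, only, none or still open, it means among the compounds named here.

Compound 1 `CC(Oc1ccc(Oc2ccc(Cl)cc2)cc1)C(=O)Cn1nnc(-c2ccc(Cl)cc2)n1` gives < 5% in an ADME assay on S9 fraction from liver (Rattus norvegicus) for metabolic stability, read by LC-MS, using NADPH, with a stated time of 30 min; on this read-out lower numbers stand for a less stable compound and higher numbers for a more stable compound; this value is a limit of the assay, not a number.
Compound 2 `CCCCCCCCc1ccc(OC(C)C(=O)Cn2nnc(-c3ccc(C(=O)OC)cc3)n2)cc1` gives 62% in this assay.

Among the compounds with values here, compound 2 thus stands as the only compound with an actual number in this assay; the other value is a limit. Compound 3 `COC(=O)c1ccc(-c2nnn(CC(=O)C(C)Oc3ccc(Oc4ccc(Cl)cc4)cc3)n2)cc1` differs from compound 2 by 4-chlorophenoxy in place of octyl on an aromatic carbon. Within the data shown here, no measured step of this kind exists. Compound 1 also carries a 4-chlorophenoxy group and sits at the limit of < 5% in this assay, at which 1 of the 2 values shown sits, so a drop beyond the scatter, toward lower stability, is expected. The expected step is a number 42 percentage points lower from compound 2 to compound 3 (beyond the scatter). Compound 3 is estimated at 20%, between 5% and 45%.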

Compound 3, percent of the compound remaining: < 5%
Compound 3 was reported as a limit; the forecaster's own chance of this, stated with the estimate: 25%; middle value at least 15 percentage points away from the limit.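

Putting 4-chlorophenoxy in place of octyl gives a number at least 57 percentage points lower from compound 2 to compound 3 (beyond the scatter) in this assay, so the group on this aromatic carbon, para to a large group, clearly matters for stability when the methoxycarbonyl group is kept. The step between compound 1 and compound 3 cannot be read, as both values are limits. Any further loss is therefore hidden at the bottom of the read-out: the limit of < 5% in this assay, at which 2 of the 3 values shown sit.

As far as these compounds go, it remains open whether a butyl chain, an amine or a carboxylic acid on this carbon would give a readable value. From the compounds shown here alone, it also remains open how chloro in place of methoxycarbonyl would act alongside octyl.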